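The source may report more compounds than this note shows. Statements on the series, on what has been measured and on what is new or still open speak of the compounds shown alone.

Measured so far in a functional assay on MCF7 cells (Homo sapiens) for cytotoxicity, read by sulforhodamine B assay, with a stated time of 48 h; a higher number here means a weaker inhibitor, a lower number a stronger inhibitor:
compound 1, `O=C(NCCCCl)Nc1cccc(S(=O)(=O)Oc2ccc(O)cc2)c1`: 51000 nM
compound 2, `O=C(NCCCCl)Nc1ccc(S(=O)(=O)Oc2ccc(O)cc2)cc1`: 51000 nM
compound 3, `Cc1ccccc1NS(=O)(=O)c1cccc(NC(=O)NCCCCl)c1`: 52000 nM

Compound 1 and compound 2 are built from the same atoms joined differently; the difference between the two cores is not broken down here. Their values in this assay sit within the usual scatter of each other. Compound 3 arises from compound 1 by (2-methylphenyl)amino in place of 4-hydroxyphenoxy on a sulfonyl sulfur and this change made a step of a 1.0-fold higher number from compound 1 to compound 3 (0.01 log units; within the scatter).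

Compound 4, `Cc1ccccc1NS(=O)(=O)c1ccc(NC(=O)NCCCCl)cc1`, is not yet measured. It arises from compound 2 by (2-methylphenyl)amino in place of 4-hydroxyphenoxy on a sulfonyl sulfur, the same change made on the same kind of place. Because the earlier step was a 1.0-fold higher number from compound 1 to compound 3 (0.01 log units; within the scatter), the step from compound 2 to compound 4 is expected to be a 1.0-fold higher number from compound 2 to compound 4 (0.01 log units; within the scatter). Compound 4 is therefore estimated at 52000 nM, with a range from 26000 nM to 104000 nM.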

Compound 4, half-maximal inhibitory concentration: > 200000 nM
Compound 4 was reported as a limit (the forecaster's own chance of this, stated with the estimate: 15%); middle value at least 3.8-fold (0.58 log units) away from the limit.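

In this assay, putting (2-methylphenyl)amino in place of 4-hydroxyphenoxy on a sulfonyl sulfur did not give the same result on the two cores: the same change on two cores in this assay, a 1.0-fold higher number (0.01 log units; within the scatter) from compound 1 to compound 3 and an at least 3.9-fold higher number (0.59 log units; beyond the scatter) from compound 2 to compound 4, at least 3.8-fold (0.58 log units) apart, beyond the scatter of two such steps

Compound 4 gives > 200000 nM, which is a limit of the assay and not a number. The step on this core, an at least 3.9-fold higher number from compound 2 to compound 4 (0.59 log units; beyond the scatter), therefore has a known lower bound but no known full size, and one pair of cores neither sets a rule for the series nor explains the gap.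

The compounds shown leave open whether a different group on the sulfonyl sulfur, such as a plain phenoxy or a simple alkyl amine, would also separate the two cores. They also leave open what a longer chain in place of the chloropropyl chain would do.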